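The compounds below may be only part of what the source reports. "The series", "measured", "known", "first", "only" and "open" are said of these compounds alone.

Working notes on the series. Compound 1 `COc1ccc(S(=O)(=O)c2cnc3c(F)cccc3c2-c2cccc(F)c2)cc1`, compound 2 `O=S(=O)(c1cc(Cl)cc(Cl)c1)c1cnc2c(F)cccc2c1-c1ccc(F)cc1` and compound 3 `O=S(=O)(c1ccc(F)cc1)c1cnc2c(F)cccc2c1-c1cccc(F)c1` have been run in an ADME assay on microsomes from liver (Homo sapiens) for metabolic stability, tested at 2.5 uM; a lower number here means slower removal, a higher number faster removal of the compound. In this assay compound 1 gives 3.03 mL/min, compound 2 gives 1.01 mL/min and compound 3 gives 1.56 mL/min. Going from compound 3 to compound 1 the change is methoxy in place of fluoro on an aromatic carbon, and the step is a 1.9-fold higher number from compound 3 to compound 1 (0.29 log units; within the scatter). The difference between the core of compound 2 and the core of compound 3 is not broken down here. Compound 4 `COc1ccc(-c2c(S(=O)(=O)c3cc(Cl)cc(Cl)c3)cnc3c(F)cccc23)cc1` has not yet been measured in this assay. It stands to compound 2 as compound 1 stands to compound 3: the change is methoxy in place of fluoro on an aromatic carbon, the same change at the same place. Because the same change gave a 1.9-fold higher number from compound 3 to compound 1 (0.29 log units; within the scatter), the step expected is a 1.9-fold higher number from compound 2 to compound 4 (0.27 log units; within the scatter). Compound 4 is estimated at 1.9 mL/min, with an expected range from 0.9 mL/min to 4 mL/min.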

Compound 4, intrinsic clearance in a liver preparation (reported as CLH), per the amount of preparation that the assay uses: 2.11 mL/min
Estimate against measurement, compound 4: 1.1-fold (0.05 log units) below; the range from low to high includes it.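

In this assay, methoxy in place of fluoro gives a 2.1-fold higher number from compound 2 to compound 4 (0.32 log units; beyond the scatter) and this sits with the earlier step on the other core: the same change on two cores in this assay, a 1.9-fold higher number (0.29 log units; within the scatter) from compound 3 to compound 1 and a 2.1-fold higher number (0.32 log units; beyond the scatter) from compound 2 to compound 4, 1.1-fold (0.03 log units) apart, within the scatter of two such steps. Within the data shown here, on these two cores the change therefore carries over with a similar size and the same direction, although only the step on the core of compound 2 lies beyond the scatter. Two pairs do not show that the step would hold on any further core, and they do not show why the number rises.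

The compounds shown leave open whether a group other than methoxy, such as an amine, a nitrile or a longer alkoxy chain, would behave alike in place of fluoro. They also leave open how such a group would read on either core.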